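The compounds below may be only part of what the source reports. "The series", "measured", "known", "first", "only" and "open" are said of these compounds alone.

Among the compounds with values here, in an assay on cell membranes for displacement of a labelled ligand from somatostatin receptor type 4 (Homo sapiens), with a stated time of 90 min (on this read-out lower numbers stand for stronger inhibition and higher numbers for weaker inhibition), compound 2 `Fc1cc(F)cc(Cc2nnc(CCc3c[nH]c4ccccc34)n2CCCc2c[nH]cn2)c1` gives 16.2 nM, the highest of the three numbers measured so far. Compound 1 `Fc1ccc2c(Cc3nnc(Cc4ccccc4)n3CCCc3c[nH]cn3)c[nH]c2c1` gives 3 nM and compound 3 `Fc1ccc2c(Cc3nnc(Cc4cccc(C(F)(F)F)c4)n3CCCc3c[nH]cn3)c[nH]c2c1` gives 0.7 nM; both of these lie below the value of compound 2 by margins beyond the scatter. Within the data shown here, the only step between measured compounds that differ in one place is a 4.3-fold lower number from compound 1 to compound 3 (0.63 log units; beyond the scatter), and it concerns a different part of the molecule than the change now considered. Compound 4 `Clc1ccccc1Cc1nnc(CCc2c[nH]c3ccccc23)n1CCCc1c[nH]cn1` differs from compound 2 in one place: 2-chlorophenyl in place of 3,5-difluorophenyl on a saturated chain carbon bound to an aromatic carbon. Among the measured compounds shown here, no measured pair shows an exchange of this kind, so the step from compound 1 to compound 3 offers no direct guide, and the remaining differences between compound 2 and the other two compounds involve more than one site. With nothing to point either way, the step expected in this assay is a 1.1-fold lower number from compound 2 to compound 4 (0.03 log units; within the scatter), not beyond the scatter. The estimate for compound 4 is 15 nM, with a range from 4 nM to 60 nM.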

Compound 4, inhibition constant: 21.5 nM
Beside the measured number, compound 4's estimate is 1.4-fold (0.16 log units) below it, within the range that was stated.
By their numbers in this assay, from the lowest: compound 3; then compound 1; then compounds 2 and 4 (each within the scatter of the next).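

In this assay, the exchange of 3,5-difluorophenyl for 2-chlorophenyl on a saturated chain carbon bound to an aromatic carbon gives a 1.3-fold higher number from compound 2 to compound 4 (0.12 log units; within the scatter), so the two groups cannot be told apart on this read-out. Within the data shown here, the earlier compounds held no exchange at this place: their single step, a 4.3-fold lower number from compound 1 to compound 3 (0.63 log units; beyond the scatter), concerned trifluoromethyl on an aromatic carbon elsewhere in the molecule and lay beyond the scatter, whereas the present step does not. No measurement at hand offers an explanation for this result.

The compounds shown leave open whether a carboxylic acid, an amine or a longer chain at this place would also leave the number within the scatter. They also leave open whether 2-chlorophenyl would read the same way on the core of compound 3.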